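The source may hold more compounds than are shown below. What is called first, only, known or untested is meant among the compounds shown, and "the series" means these compounds.

In a functional assay on CCRF-CEM cells (Homo sapiens) for antiproliferative activity, read by cell counting, with a stated time of 72 h (a higher number here means a weaker inhibitor, a lower number a stronger inhibitor), two compounds have been measured so far, and they sit far apart. Compound 1 `C#C[C@@]1(O)[C@@H](CO)O[C@@H](n2cnc3c(-c4ccc(OC)cc4)ncnc32)[C@@H]1O` yields no exact figure: its result is a limit of the assay, > 250000 nM. As the limit of > 250000 nM in this assay, at which 1 of the 2 values shown sits, shows, this is the only such limit among the results. Among the compounds with values here, compound 2 `C#C[C@@]1(O)[C@@H](CO)O[C@@H](n2cc(F)c3c(N)ncnc32)[C@@H]1O` gives 160 nM, the only true number available, and so the sole numerical reference point for what follows.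

Compound 3 `C#C[C@@]1(O)[C@@H](CO)O[C@@H](n2cc(I)c3c(N)ncnc32)[C@@H]1O` departs from compound 2 at a single place: iodo in place of fluoro on an aromatic carbon. This is iodo in place of fluoro on an aromatic carbon, on a five-membered aromatic ring with 1 nitrogen that is part of a fused or bridged system of two rings, two ring bonds from the ring nitrogen. Within the data shown here, no measured pair here shows what exchanging one halogen for another does in this assay, so the expectation rests on judgement and stays wide. A modest weakening, somewhat beyond the usual scatter, seems the most likely outcome. The expected change is a 1.9-fold higher number from compound 2 to compound 3 (0.27 log units; within the scatter). Compound 3 is estimated at 300 nM, with an expected range of 50 nM to 2500 nM.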

Compound 3, half-maximal inhibitory concentration: 120 nM
The estimate for compound 3 lay 2.5-fold (0.40 log units) above the measured number; the range from low to high includes it.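

In this assay the exchange of iodo for fluoro on an aromatic carbon of the five-membered aromatic ring with 1 nitrogen gives a 1.3-fold lower number from compound 2 to compound 3 (0.12 log units; within the scatter) and so stays within the usual scatter of repeated measurements. This is the only pair shown that differs in one place, and it gives the first direct reading at this position: a fluoro and an iodo substituent, the two halogens shown here, cannot be told apart by their values in this cell assay, and both compounds keep measurable antiproliferative activity. The only other result at hand concerns a limit reached by a different compound and does not bear on this comparison between the two halogens.

The compounds shown leave open whether chloro or bromo at the same carbon would give similar values, and whether the position would tolerate a group that is not a halogen, such as a methyl, an amine, a nitrile or a carboxylic acid. They also leave open what a longer chain or an added ring at this carbon would do to activity in this assay in these cells.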